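Amide nitrogen substituents on a benzyloxy benzamide core

A few compounds are considered here, and "the series" means these few. Any claim that something is new, unique, unknown or untested is made for them only; others in the source may bear on it.

Measured so far:
compound 1 `O=C(NCc1ccco1)c1ccccc1OCc1ccccc1` gives 49000 nM in an assay on lysate for inhibition of phosphatidylcholine:ceramide cholinephosphotransferase 2 (Homo sapiens), read by HPLC, with stated times of 30 min and 2 h; a lower number here means a stronger inhibitor, a higher number a weaker inhibitor
compound 2 `O=C(NC1CCCCC1)c1ccccc1OCc1ccccc1` gives 43400 nM in this assay

Compound 2 and compound 1 stand within the scatter of each other in this assay, the step of a 1.1-fold lower number from compound 1 to compound 2 (0.05 log units; within the scatter) being the only one measured. Compound 3 `O=C(Nc1ccccn1)c1ccccc1OCc1ccccc1` differs from compound 2 by pyridin-2-yl in place of cyclohexyl on an amide-type nitrogen. For the measured compounds named here, no measured step changes cyclohexyl for an aromatic ring, so the single step from compound 1 to compound 2 bears on it only loosely. As that step stayed within the scatter, the expected step of a 1.1-fold lower number from compound 2 to compound 3 (0.04 log units; within the scatter) is likewise small. Compound 3 is therefore estimated at 40000 nM, with a range from 15000 nM to 120000 nM.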

Compound 3, half-maximal inhibitory concentration: 11700 nM
The estimate for compound 3 lay 3.4-fold (0.53 log units) above the measured number; measured number outside the range, below it.
By their numbers in this assay, from the lowest: compound 3; then compounds 2 and 1 (each within the scatter of the next).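

In this assay, the substituent on this amide-type nitrogen does matter: pyridin-2-yl gives a 3.7-fold lower number from compound 2 to compound 3 (0.57 log units; beyond the scatter) and a 4.2-fold lower number from compound 1 to compound 3 (0.62 log units; beyond the scatter), whereas the earlier change of substituent stayed within the scatter. Against cyclohexyl, the heavy-atom count stays the same, while the ring becomes aromatic and gains a nitrogen and a hydrogen-bond acceptor. No supporting data tie the step to either feature.

Phenyl on the same nitrogen would separate the aromatic ring from its ring nitrogen. As far as these compounds go, whether pyridin-3-yl or pyridin-4-yl would match pyridin-2-yl remains open.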